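This account rests on a few compounds, and the source may have more. Where it says the series, first, only, none or still open, it means among the compounds named here.

Among the compounds with values here, compound 2 `Cc1ccc(/C=C(\C(=O)c2ccc(Br)cc2)S(=O)(=O)Cc2ccc(F)cc2)s1` holds the lowest of the two numbers so far in a functional assay on DU-145 cells (Homo sapiens) for inhibition, read by trypan blue exclusion, with a stated time of 96 h (on this read-out lower numbers stand for stronger inhibition of growth and higher numbers for weaker inhibition of growth), where compound 2 gives 1000 nM. Within the data shown here, its only neighbour, compound 1 `CSc1ccc(/C=C(\C(=O)c2ccc(Br)cc2)S(=O)(=O)Cc2ccc(F)cc2)cc1`, gives 50000 nM in this assay, and the single step in hand, a 50-fold lower number from compound 1 to compound 2 (1.70 log units; beyond the scatter), is the exchange of 4-(methylsulfanyl)phenyl for 5-methylthiophen-2-yl on the double-bonded chain carbon bound to a double-bonded chain carbon. Compound 3 `O=C(/C(=C\c1ccc(Br)cc1)S(=O)(=O)Cc1ccc(F)cc1)c1ccc(Br)cc1` differs from compound 2 at the same place: 4-bromophenyl in place of 5-methylthiophen-2-yl on a double-bonded chain carbon bound to a double-bonded chain carbon. The step bearing on it is a 50-fold lower number from compound 1 to compound 2 (1.70 log units; beyond the scatter), which rewarded the five-membered ring over a six-membered one; compound 3 returns to a six-membered ring of carbon only, though with bromine rather than methylsulfanyl, so the result need not match compound 1. A higher number is expected for compound 3, with a 10-fold higher number from compound 2 to compound 3 (1.00 log units; beyond the scatter) as the expected step. The estimate for compound 3 in this assay is 10000 nM, within 2000 nM to 50000 nM.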

Compound 3, concentration for 50% growth inhibition: 25000 nM
The estimate for compound 3 lay 2.5-fold (0.40 log units) below the measured number; measured number inside the range.
By their numbers in this assay, from the lowest: compound 2; then compounds 3 and 1 (each within the scatter of the next).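

In this assay, the step of a 25-fold higher number from compound 2 to compound 3 (1.40 log units; beyond the scatter) shows that the low number of compound 2 does not survive a return to a six-membered ring of carbon only, even with bromine in place of methylsulfanyl. Within the data shown here, the step of a 2.0-fold lower number from compound 1 to compound 3 (0.30 log units; within the scatter) gives no readable difference between the two para-free phenyl groups tested, 4-bromophenyl and 4-(methylsulfanyl)phenyl, so the exchange of bromo for methylsulfanyl on an aromatic carbon carries no effect in this pair. Of the three groups on this double-bonded chain carbon, only 5-methylthiophen-2-yl stands apart, and both of its steps lie beyond the scatter.

From the compounds shown here alone, whether an unsubstituted thiophen-2-yl, a furan-2-yl or a pyridin-3-yl at this place would keep the number of compound 2 stays open. Nothing in hand bears on why 5-methylthiophen-2-yl stands apart.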